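The source may hold more compounds than are shown below. What is called first, only, known or untested is meant among the compounds shown, and "the series" means these compounds.

The measured compounds in a functional assay on CAKI-1 cells (Homo sapiens) for inhibition, read by sulforhodamine B assay, with a stated time of 48 h, tested at 10 uM; a lower number here means less inhibition of growth, a higher number more inhibition of growth at the concentration tested:
compound 1, `CCOC(=O)c1ccc(Nc2ccnc(SCC(=O)c3ccc(C#N)cc3)n2)cc1`, gives 43%
compound 2, `CC(=O)c1cccc(Nc2ccnc(SCC(=O)c3ccc(-c4ccccc4)cc3)n2)c1`, gives 23%
compound 3, `COc1ccc(C(=O)CSc2nccc(Nc3cccc(C(C)=O)c3)n2)cc1`, gives 35%

Compound 2 sits at the bottom of these three numbers. Its nearest neighbour is reached by a number 12 percentage points higher from compound 2 to compound 3 (beyond the scatter), a change at the other end of the molecule from the acetylphenyl group. Going by the values given here, compound 1 lies further off still, and no single step links it to compound 2, since the two differ in more than one place.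

Compound 4, `CC(=O)c1ccc(Nc2ccnc(SCC(=O)c3ccc(-c4ccccc4)cc3)n2)cc1`, has not yet been measured. It differs from compound 2 by 4-acetylphenyl in place of 3-acetylphenyl on a nitrogen on an aromatic ring. Among the compounds with values here, no measured pair shows this change: the only step recorded among the three compounds, the one from compound 2 to compound 3, swaps methoxy for phenyl and leaves the acetylphenyl group as it is. Nothing in the numbers therefore points to a move in either direction, and the expectation is a step that stays within the usual scatter. Compound 4 is accordingly expected to give about 25% in this assay, somewhere between 10% and 42%, which means an expected a number 2 percentage points higher from compound 2 to compound 4 (within the scatter).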

Compound 4, percent growth inhibition at one concentration: 16%
Compound 4: middle estimate off by 9 percentage points, on the high side; the measured number falls inside the stated range.
By their numbers in this assay, from the lowest: compounds 4 and 2 (each within the scatter of the next); then compounds 3 and 1 (each within the scatter of the next).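

In this assay, going by these compounds alone, the exchange of 3-acetylphenyl for 4-acetylphenyl on the nitrogen gives a number 7 percentage points lower from compound 2 to compound 4 (within the scatter), and this is the first step that reports on this end of the molecule. Within the data shown here, the two groups have the same atoms and differ only in how they are joined, so within this pair the read-out does not separate them, whereas the only earlier step, a number 12 percentage points higher from compound 2 to compound 3 (beyond the scatter), came from the other end of the molecule and lay beyond the scatter. No measured information is available to explain the result at this position.

What the compounds shown leave open is whether the two acetylphenyl groups would also read alike with methoxy in place of phenyl at the other end, as in compound 3, since a single pair cannot show whether the result carries over to another partner. Going by these compounds, it also remains open how this position would respond to a different group on the aromatic ring in place of acetyl, such as a carboxylic acid or an amine.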